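A few compounds are considered here, and "the series" means these few. Any claim that something is new, unique, unknown or untested is made for them only; others in the source may bear on it.

For the measured compounds named here, compound 2 `O=C(NS(=O)(=O)CCNCc1ccccc1)c1ccc(Nc2nc(NC3(c4ccc(Cl)cc4)CC3)nc(OCC(F)(F)F)n2)cc1` is the lower of the two compounds measured so far in a physicochemical assay for permeability, using PAMPA, at pH 7.4; a higher number here means that the compound crosses the layer faster, a lower number that the compound crosses the layer more slowly: compound 2 gives 49 nm/s, whereas compound 1 `CC(C)(C)CNCCS(=O)(=O)NC(=O)c1ccc(Nc2nc(NC3(c4ccc(Cl)cc4)CC3)nc(OCC(F)(F)F)n2)cc1` gives 651 nm/s. Going by the values given here, the one step between them, a 13-fold lower number from compound 1 to compound 2 (1.12 log units; beyond the scatter), is the only measured step. Compound 3 `Cc1ccccc1S(=O)(=O)NC(=O)c1ccc(Nc2nc(NC3(c4ccc(Cl)cc4)CC3)nc(OCC(F)(F)F)n2)cc1` differs from compound 2 by 2-methylphenyl in place of 2-(benzylamino)ethyl on a sulfonyl sulfur. Among the compounds with values here, no measured step matches this change, since the step from compound 1 to compound 2 swaps one group on the chain carbon while the chain itself stays; here the whole 2-(benzylamino)ethyl chain leaves and a 2-methylphenyl sits directly on the sulfonyl sulfur. That single step shows how strongly a change at this end of the molecule can move this assay, so a step beyond the scatter is expected, upward, as a 4.1-fold higher number from compound 2 to compound 3 (0.61 log units; beyond the scatter). Compound 3 is therefore estimated at 200 nm/s, with a range from 50 nm/s to 800 nm/s.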

Compound 3, apparent permeability: 265 nm/s
Compound 3: the middle estimate sits 1.3-fold (0.12 log units) below what was measured; the measured number falls inside the stated range.
By their numbers in this assay, from the lowest: compound 2; then compound 3; then compound 1.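

In this assay the same entering group, 2-methylphenyl on the sulfonyl sulfur, moves the number in opposite directions depending on the chain it replaces, giving a 5.4-fold higher number from compound 2 to compound 3 (0.73 log units; beyond the scatter) in place of 2-(benzylamino)ethyl and a 2.5-fold lower number from compound 1 to compound 3 (0.39 log units; beyond the scatter) in place of 2-(neopentylamino)ethyl. The two compounds with an amine in the chain thus lie on either side of compound 3, so among these three compounds the presence of that nitrogen alone does not set the order. Nothing on hand accounts for these differences.

The three compounds leave open whether the methyl of the 2-methylphenyl group matters, which a plain phenyl on the sulfonyl sulfur would test. Also open, from the compounds shown here alone, is how a short alkyl group such as methyl, or a chain ending in a carboxylic acid, would read at this place.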